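Chloro to bromo swap at the para position of an aryl group

The compounds below may be only part of what the source reports. "The series", "measured", "known", "first", "only" and "open" are said of these compounds alone.

Compound 1 `COc1cc(-c2nc(SCc3cn(Cc4ccccc4Cl)nn3)nc(Nc3ccc(C)cc3)c2C#N)cc(OC)c1OC`: 30800 nM
Compound 2 `Cc1ccc(Nc2nc(SCc3cn(Cc4ccccc4Cl)nn3)nc(-c3ccc(Cl)cc3)c2C#N)cc1`: 18500 nM

In a functional assay on MGC-803 cells (Homo sapiens) for inhibition, read by MTT assay, with a stated time of 72 h (on this read-out higher numbers stand for weaker inhibition and lower numbers for stronger inhibition), compound 2 gives 18500 nM, the lower of the two numbers, though only by a 1.7-fold lower number from compound 1 to compound 2 (0.22 log units; within the scatter), a step within the scatter. Compound 3 `Cc1ccc(Nc2nc(SCc3cn(Cc4ccccc4Cl)nn3)nc(-c3ccc(Br)cc3)c2C#N)cc1` differs from compound 2 by bromo in place of chloro on an aromatic carbon. Among the measured steps only the one from compound 1 to compound 2, which also changes this aryl group, bears on it, and it stayed within the scatter. A like-for-like halogen exchange is therefore expected to move this assay little, if at all. Compound 3 is accordingly estimated at 16000 nM (range 7000 nM to 40000 nM), an expected step of a 1.2-fold lower number from compound 2 to compound 3 (0.06 log units; within the scatter).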

Compound 3, half-maximal inhibitory concentration: 15600 nM
Compound 3: the middle estimate sits 1.0-fold (0.01 log units) above what was measured, within the range that was stated.
By their numbers in this assay, from the lowest: compounds 3, 2 and 1 (each within the scatter of the next).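

In this assay, the exchange of chloro for bromo on this aryl group comes with a 1.2-fold lower number from compound 2 to compound 3 (0.07 log units; within the scatter), so the two halogens cannot be told apart at this place. Set against 3,4,5-trimethoxyphenyl, the 4-bromophenyl group comes with a 2.0-fold lower number from compound 1 to compound 3 (0.30 log units; within the scatter), so all three aryl groups shown read alike within the scatter. Nothing available offers an explanation for these readings. The compounds shown leave open whether an amine or a carboxylic acid on this ring would move the number beyond the scatter.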